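The source may hold more compounds than are shown below. What is called first, only, known or untested is meant among the compounds shown, and "the series" means these compounds.

Compound 3 `O=C(CN(c1nc(Cl)nc2[nH]cnc12)C1CC1)NCC(=O)OCc1ccccc1` stands at the top of the three numbers in a functional assay on the whole organism (Tail, strain ICR) with Mus musculus as the target, in the tail flick test, with a stated time of 150 min, at a dose of 25 umol/kg by the oral route (on this read-out lower numbers stand for a weaker effect and higher numbers for a stronger effect at the one dose given), where compound 3 gives 18%. Compound 2 `NCCCC[C@H](NC(=O)CN(c1nc(Cl)nc2[nH]cnc12)C1CC1)C(=O)OCc1ccccc1` gives 9.88%, and compound 1 `O=C(CN(c1nc(Cl)nc2[nH]cnc12)C1CC1)N[C@@H](CC(=O)OCc1ccccc1)C(=O)OCc1ccccc1` gives 6.68%. The steps to compound 3 were a number 11.3 percentage points higher from compound 1 to compound 3 (beyond the scatter) and a number 8.1 percentage points higher from compound 2 to compound 3 (within the scatter), while a number 3.2 percentage points higher from compound 1 to compound 2 (within the scatter). Compound 4 `C[C@H](NC(=O)CN(c1nc(Cl)nc2[nH]cnc12)C1CC1)C(=O)OCc1ccccc1` differs from compound 3 by methyl in place of hydrogen on a saturated chain carbon bound to an amide-type nitrogen and a carbonyl carbon. Both steps to compound 3 bear on this place: removing a larger group there raised the number only modestly or not beyond the scatter, so a methyl entering there is expected to change this assay little, perhaps a small drop within the scatter, an expected step of a number 3 percentage points lower from compound 3 to compound 4 (within the scatter). Compound 4 is therefore estimated at 15%, between 5% and 28%.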

Compound 4, a percentage reported as activity, at one dose (the size of the read-out at that dose, not a potency): 23%
Compound 4: the middle estimate sits 8 percentage points below what was measured, within the range that was stated.
By their numbers in this assay, from the lowest: compounds 1, 2, 3 and 4 (each within the scatter of the next, the first and the last beyond it).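

In this assay methyl in place of hydrogen on this saturated chain carbon gives a number 5 percentage points higher from compound 3 to compound 4 (within the scatter) and so shows no loss with this small group. Set against the larger side chains, the methyl gives a number 13.1 percentage points higher from compound 2 to compound 4 (beyond the scatter) and a number 16.3 percentage points higher from compound 1 to compound 4 (beyond the scatter) and thus compound 4, unlike compound 3, stands beyond the scatter from both. No measurement shown here accounts for these steps.

Going by these compounds, whether an ethyl or isopropyl group at this carbon would hold this level remains open. So do the opposite configuration there and a free carboxylic acid in place of the benzyl ester.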